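This account rests on a few compounds, and the source may have more. Where it says the series, first, only, none or still open, it means among the compounds named here.

Measured compounds in an assay on microsomes from brain for inhibition of Fatty-acid amide hydrolase 1 (Rattus norvegicus), read by fluorescence and HPLC, with a stated time of 60 min; on this read-out higher numbers stand for weaker inhibition and lower numbers for stronger inhibition:
Compound 1 `CCCCCCCCc1ccc(OCC(=O)Cn2nnc(-c3cccc(C(=O)OC)c3)n2)cc1` gives 34 nM.
Compound 2 `CCCCCCCCc1ccc(OCC(=O)Cn2nnc(-c3ccccn3)n2)cc1` gives 18 nM.
Compound 3 `CCCCCCCCc1ccc(OCC(=O)Cn2nnnc2-c2ccccc2Cl)cc1` gives 4600 nM.

Compound 3 has the highest of the three numbers, that is, the weakest inhibition; compound 1 is the nearest and compound 2 the furthest, both gaps beyond the scatter. The unmeasured compound 4 `CCCCCCCCc1ccc(OCC(=O)Cn2nnnc2C(=O)OCC)cc1` differs from compound 3 in one place: ethoxycarbonyl in place of 2-chlorophenyl on an aromatic carbon. For the measured compounds named here, the only measured step, a 1.9-fold lower number from compound 1 to compound 2 (0.28 log units; within the scatter), swaps one aromatic group for another on the core of compound 1 and lies within the scatter, so it says little about replacing 2-chlorophenyl with ethoxycarbonyl on the core of compound 3. Lacking a directly comparable step, the expectation is a modest move toward stronger inhibition with a wide range. Compound 4 is therefore estimated at 1500 nM, from 300 nM to 8000 nM. This corresponds to an expected step of a 3.1-fold lower number from compound 3 to compound 4 (0.49 log units; beyond the scatter).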

Compound 4, half-maximal inhibitory concentration: 940 nM
For compound 4 the middle estimate is 1.6-fold (0.20 log units) above the measured one, within the range that was stated.
By their numbers in this assay, from the lowest: compounds 2 and 1 (each within the scatter of the next); then compound 4; then compound 3.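

In this assay, putting ethoxycarbonyl in place of 2-chlorophenyl gives a 4.9-fold lower number from compound 3 to compound 4 (0.69 log units; beyond the scatter), a modest step toward stronger inhibition. This shows that, on the core of compound 3, this aromatic carbon does not need an aromatic ring for inhibition to hold, since a group with no ring does better there than 2-chlorophenyl. Nothing available explains this step. Still open, on these data alone, is which part of ethoxycarbonyl matters: a carboxylic acid, a primary amide or a methyl ester at this carbon would help separate the parts. An unsubstituted phenyl there would show what the chlorine contributes.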